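Shortening the Long Chain on Compound 2

This account rests on a few compounds, and the source may have more. Where it says the series, first, only, none or still open, it means among the compounds named here.

Two compounds share a core and differ only in the group carried on a double-bonded nitrogen. Compound 1 `Nc1n/c(=N\CCCCc2ccccc2)nc(N)c2c1ncn2Cc1ccccc1` carries a short chain ending in a phenyl group, while compound 2 `CCCCCCCCCCCCCCCCCC/N=c1\nc(N)c2ncn(Cc3ccccc3)c2c(N)n1` carries a long saturated chain. In a functional assay on MDA-MB-231 cells (Homo sapiens) for antiproliferative activity, read by WST assay, with a stated time of 72 h (a higher number here means a weaker inhibitor, a lower number a stronger inhibitor), compound 1 gives 16700 nM, and compound 2 gives 5400 nM, the lower of the two numbers; the gap between them is beyond the usual scatter, so compound 2 is the stronger inhibitor of the pair.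

Compound 3 `CCCCCCCCCCCCCC/N=c1\nc(N)c2ncn(Cc3ccccc3)c2c(N)n1` keeps the long saturated chain but cuts its far end: hydrogen in place of butyl on a saturated chain carbon, ten or more bonds along the chain from a double-bonded nitrogen. For the measured compounds named here, no measured pair shows the effect of such a cut, so the direction is open. Because compound 2 gives 5400 nM with the longer chain, the expectation is that compound 3 sits close to it, with a step from compound 2 to compound 3 of a 1.5-fold higher number from compound 2 to compound 3 (0.17 log units; within the scatter) that stays within the scatter or leans toward a slightly weaker inhibitor. Compound 3 is therefore estimated at 8000 nM, within a range from 3000 nM to 25000 nM.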

Compound 3, half-maximal inhibitory concentration: 5850 nM
The estimate for compound 3 lay 1.4-fold (0.14 log units) above the measured number, and the stated range covers the measured number.
By their numbers in this assay, from the lowest: compounds 2 and 3 (each within the scatter of the next); then compound 1.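

In this assay, for the compounds shown here, the step of a 1.1-fold higher number from compound 2 to compound 3 (0.03 log units; within the scatter) shows for the first time what happens when butyl gives way to hydrogen on a saturated chain carbon: the two numbers cannot be told apart. That outer stretch of the chain can therefore go without a readable loss in this assay, and the full length of compound 2 is not needed to keep its level. Placing decyl in place of phenyl on a saturated chain carbon, four bonds along the chain from a double-bonded nitrogen, gives a 2.9-fold lower number from compound 1 to compound 3 (0.46 log units; beyond the scatter), a modest step that separates the shortened saturated chain from the phenyl-ended chain, though nothing here explains either result.

Going by these compounds, how far the chain can be shortened before the number moves remains open, and a much shorter chain such as octyl or butyl would test that limit. On these data alone, it is also open whether an amine or a carboxylic acid in place of that butyl would leave the number unchanged, as hydrogen does.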